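A Methyl Added to the Anilino Ring

A few compounds are considered here, and "the series" means these few. Any claim that something is new, unique, unknown or untested is made for them only; others in the source may bear on it.

Two compounds share one core. Compound 1 `CCOC(=O)c1c(-c2ccc(Cl)cc2)cc(-c2ccccc2)nc1N1CCN(C)CC1` carries a 4-methylpiperazin-1-yl group on an aromatic carbon, and in a functional assay on the whole organism (strain Wister albino) for inhibition, with Rattus norvegicus as the target, read by paw edema, with stated times of 1 h and 4 h, at a dose of 50 mg/kg by the intraperitoneal route (on this read-out lower numbers stand for less inhibition and higher numbers for more inhibition at the one dose given (going by the name of the read-out)), compound 1 gives 37.8%. Compound 2 `CCOC(=O)c1c(-c2ccc(Cl)cc2)cc(-c2ccccc2)nc1Nc1ccccc1` carries an anilino group at that carbon instead, and in this assay compound 2 gives 83.8%, the higher of the two numbers. Among the compounds with values here, the single measured step, a number 46 percentage points higher from compound 1 to compound 2 (beyond the scatter), comes from anilino in place of 4-methylpiperazin-1-yl on an aromatic carbon.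

Compound 3 `CCOC(=O)c1c(-c2ccc(Cl)cc2)cc(-c2ccccc2)nc1Nc1ccc(C)cc1` keeps the anilino group of compound 2 and differs from it in one place: methyl in place of hydrogen on an aromatic carbon. Within the data shown here, no measured step shows what a methyl in place of hydrogen on an aromatic carbon does, so nothing speaks for a step beyond the scatter in this assay. The expected step is a number 3.8 percentage points lower from compound 2 to compound 3 (within the scatter). Compound 3 is therefore estimated at 80%, with a range from 65% to 92%.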

Compound 3, a percentage reported as inhibition, in the whole organism at one dose (the size of the read-out at that dose, not a potency): 61.8%
Beside the measured number, compound 3's estimate is 18.2 percentage points above it; the measured number lies below the stated range.
By their numbers in this assay, from the lowest: compound 1; then compound 3; then compound 2.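

In this assay, the outer carbon of the anilino ring turns out to matter: a single methyl there, para to a large group, gives a number 22 percentage points lower from compound 2 to compound 3 (beyond the scatter). The gain over the 4-methylpiperazin-1-yl group survives this change but is smaller, since (4-methylphenyl)amino in its place still gives a number 24 percentage points higher from compound 1 to compound 3 (beyond the scatter). No measurement at hand bears on what lies behind the drop caused by the methyl.

One methyl at one carbon cannot show whether any added group there lowers the number or only this one, and a chlorine, a methoxy or a hydroxyl on that same carbon would help to separate the two. The compounds shown also leave open whether a methyl on another carbon of the anilino ring would give a similar step.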